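Swapping the thiophene of compound 2 for a furan

The source may hold more compounds than are shown below. What is called first, only, known or untested is meant among the compounds shown, and "the series" means these compounds.

The series rests on one shared core carrying a hydroxyphenyl group, a chlorophenyl group and a five-membered heteroaryl ring. Compound 1 `Oc1ccc(-c2cc(-c3ccc(Cl)cc3)nc(-c3ccsc3)c2)cc1` is the most active of the three measured, giving 47.7% in an assay on isolated protein for inhibition of DNA topoisomerase 1 (Homo sapiens), with a stated time of 30 min, tested at 100 uM; on this read-out higher numbers stand for a stronger effect at the one concentration tested and lower numbers for a weaker effect. Compound 2 `Oc1cccc(-c2cc(-c3ccc(Cl)cc3)nc(-c3ccsc3)c2)c1` stands lowest of the three, with 11.7% in this assay. Compound 3 `Oc1cccc(-c2cc(-c3ccsc3)nc(-c3cccc(Cl)c3)c2)c1` gives 26.2% in this assay, placing it between the other two.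

Compound 4 `Oc1cccc(-c2cc(-c3ccc(Cl)cc3)nc(-c3ccco3)c2)c1` is the compound not yet measured. It differs from compound 2 in a single place: furan-2-yl in place of thiophen-3-yl on an aromatic carbon. Neither of the two measured steps touches this ring. The step of a number 36 percentage points lower from compound 1 to compound 2 (beyond the scatter) concerns the hydroxyphenyl group, and the step of a number 14.5 percentage points higher from compound 2 to compound 3 (beyond the scatter) concerns the chlorophenyl group; the thiophen-3-yl ring is kept unchanged in compounds 1, 2 and 3. There is thus no measured evidence on the effect of the furan-2-yl for thiophen-3-yl exchange. Both rings are five-membered aromatic rings with one hetero atom and one hydrogen-bond acceptor, so a change no larger than the scatter is expected, in no firm direction, that is an expected step of a number 3.3 percentage points higher from compound 2 to compound 4 (within the scatter). Compound 4 is therefore estimated at 15% in this assay, with a range from 2% to 35%.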

Compound 4, a percentage reported as inhibition, at one concentration (the size of the read-out at that concentration, not a potency): 27.1%
For compound 4 the middle estimate is 12.1 percentage points below the measured one; the range from low to high includes it.
By their numbers in this assay, from the lowest: compound 2; then compounds 3 and 4 (each within the scatter of the next); then compound 1.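

In this assay, the five-membered ring next to the ring nitrogen proves to be a third place in the series where a single exchange moves the read-out: furan-2-yl in place of thiophen-3-yl gives a number 15.4 percentage points higher from compound 2 to compound 4 (beyond the scatter). Within the data shown here, the earlier steps concerned only the hydroxyphenyl and chlorophenyl groups, so this is the first sign that the read-out also responds to this ring, even though the two rings match in ring size, heavy-atom count and counted hydrogen-bond acceptors. Nothing shown here accounts for the step.

The exchange alters the hetero atom, sulfur to oxygen, and the point of attachment together, so the compounds shown leave open which of the two goes with the step, a question that thiophen-2-yl or furan-3-yl at this place would address. They also leave open whether the same exchange holds alongside the 4-hydroxyphenyl group of compound 1 or the 3-chlorophenyl group of compound 3, and how a morpholine or a simple amine would behave here in place of an aromatic ring.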